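Methylsulfamoyl in place of trifluoromethyl on the shared core

The compounds below may be only part of what the source reports. "The series", "measured", "known", "first", "only" and "open" are said of these compounds alone.

Measured so far:
Compound 1, `CCCS(=O)(=O)Nc1ccc(F)c(C(=O)c2n[nH]c3ncc(-c4ccc(C(C)(C)C)cc4)cc23)c1F`, gives 46% in an assay for binding affinity to dual specificity mitogen-activated protein kinase kinase 4 (Homo sapiens), read by KINOMEscan, tested at 100 nM; a lower number here means a stronger effect, a higher number a weaker effect of the compound at the concentration tested.
Compound 2, `CCCS(=O)(=O)Nc1ccc(F)c(C(=O)c2n[nH]c3ncc(-c4ccc(C(F)(F)F)cc4)cc23)c1F`, gives 29% in this assay.

Compound 2 holds the lower of the two numbers; its nearest neighbour is compound 1, and the step of a number 17 percentage points lower from compound 1 to compound 2 (beyond the scatter) lies beyond the scatter. Compound 3, `CCCS(=O)(=O)Nc1ccc(F)c(C(=O)c2n[nH]c3ncc(-c4ccc(S(=O)(=O)NC)cc4)cc23)c1F`, is built from compound 2 by the change (methylsulfamoyl in place of trifluoromethyl on an aromatic carbon). For the measured compounds named here, only one measured step touches the same place on the ring, a number 17 percentage points lower from compound 1 to compound 2 (beyond the scatter), and it exchanged two different groups, so it gives only a weak guide here: it shows that a group swap at this position can move the read-out by a modest amount in either direction. Going by the values given here, the methylsulfamoyl group appears in no measured compound, so the expected size is uncertain. For compound 3 the estimate is 45%, within 12% to 85%. This means an expected step of a number 16 percentage points higher from compound 2 to compound 3 (beyond the scatter).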

Compound 3, a percentage reported as activity, at one concentration (the size of the read-out at that concentration, not a potency): 1.2%
Estimate against measurement, compound 3: 43.8 percentage points above; measured number below the stated range.
By their numbers in this assay, from the lowest: compound 3; then compound 2; then compound 1.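

At this place on the ring, methylsulfamoyl gives the lowest number of the three compounds in this assay, with a number 27.8 percentage points lower from compound 2 to compound 3 (beyond the scatter) and a number 44.8 percentage points lower from compound 1 to compound 3 (beyond the scatter) as its two steps. The earlier compounds shown here offered only an exchange between tert-butyl and trifluoromethyl, so they covered groups built from carbon with hydrogen or fluorine. Compound 3 adds a different kind of group, one containing sulfur, oxygen and nitrogen, and with it the number in this assay falls further than the earlier swap had taken it.

From the compounds shown here alone, how a plain sulfamoyl, a dimethylsulfamoyl or a carboxylic acid at this place would read remains open. No measurement available here accounts for the difference between methylsulfamoyl and the other two groups.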